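Branching the Chain on the Shared Core

This account rests on a few compounds, and the source may have more. Where it says the series, first, only, none or still open, it means among the compounds named here.

Measured so far:
compound 1, `C=CCOCCn1c(N2CCCN(C)CC2)nc2ccccc21`: 10 nM
compound 2, `CCCCCCn1c(N2CCN(C)CC2)nc2ccccc21`: 26 nM

The account follows compound 2 and compound 3. In a functional assay on ileum for inhibition of histamine H1 receptor (Cavia porcellus) (a lower number here means a stronger inhibitor, a higher number a weaker inhibitor), compound 2 gives 26 nM, the highest number among the two measured compounds; compound 1 gives 10 nM, a lower number, and that gap lies beyond the usual scatter. For the measured compounds named here, no step between measured compounds that differ in one place is available, so the two values show only where each compound stands.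

Compound 3, `CCCC(C)Cn1c(N2CCN(C)CC2)nc2ccccc21`, is not yet measured in this assay. It differs from compound 2 by 1-methylbutyl in place of pentyl on a saturated chain carbon bound to an aromatic nitrogen. In the words given, this puts 1-methylbutyl in place of pentyl on a saturated chain carbon bound to an aromatic nitrogen.

Going by the values given here, with no measured step of this kind to rest on, the expected step is small, in the direction of a somewhat higher number, or none beyond the scatter, so the estimate for compound 3 is 35 nM, with a range from 15 nM to 90 nM, meaning an expected step of a 1.3-fold higher number from compound 2 to compound 3 (0.13 log units; within the scatter) in this assay.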

Compound 3, half-maximal inhibitory concentration: 500 nM
Estimate against measurement, compound 3: 14-fold (1.15 log units) below; measured number above the stated range.
By their numbers in this assay, from the lowest: compound 1; then compound 2; then compound 3.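

In this assay, the change to 1-methylbutyl in place of pentyl on a saturated chain carbon bound to an aromatic nitrogen brings a 19-fold higher number from compound 2 to compound 3 (1.28 log units; beyond the scatter). For the compounds shown here, this is the first comparison in the account between compounds that differ in one place, and it shows that this position is sensitive to how the chain is joined, not only to which atoms it holds. The two groups have the same count of heavy atoms and differ only in the branch, yet the step is large. Nothing available here bears on why this branch has so large an effect. The compounds shown leave open whether an unbranched longer chain such as heptyl, or a ring such as cyclopentyl, would be tolerated at this position.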